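The source may report more compounds than this note shows. Statements on the series, on what has been measured and on what is new or still open speak of the compounds shown alone.

Measured so far in a functional assay on A549 cells (Homo sapiens) for inhibition, read by CCK-8 assay, with a stated time of 48 h; on this read-out higher numbers stand for weaker inhibition and lower numbers for stronger inhibition:
- compound 1 `COc1ccc(-c2cc3nccc(-c4cc(OC)c(OC)c(OC)c4)n3n2)cc1N` gives 138 nM
- compound 2 `COc1cc(-c2ccnc3cc(-c4ccc5cc[nH]c5c4)nn23)cc(OC)c1OC` gives 170 nM
- compound 3 `COc1ccc(-c2cc3nccc(-c4cc(OC)c(OC)c(OC)c4)n3n2)cc1` gives 376 nM

Compound 1 has the lowest number of the three. Compound 2 is within the scatter of it: a 1.2-fold higher number from compound 1 to compound 2 (0.09 log units; within the scatter). Compound 3 is the only one clearly apart: a 2.7-fold higher number from compound 1 to compound 3 (0.44 log units; beyond the scatter).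

Next is compound 4 `COc1cc(-c2ccnc3cc(-c4cn(C)c5ccccc45)nn23)cc(OC)c1OC`. 1-methyl-1H-indol-3-yl in place of 3-amino-4-methoxyphenyl on an aromatic carbon

Among the measured compounds shown here, two measured steps bear on this. Swapping the same 3-amino-4-methoxyphenyl for 1H-indol-6-yl gave a 1.2-fold higher number from compound 1 to compound 2 (0.09 log units; within the scatter), so an indole in this place has once been carried at no cost. Dropping the amino alone gave a 2.7-fold higher number from compound 1 to compound 3 (0.44 log units; beyond the scatter), and a 2.2-fold higher number from compound 2 to compound 3 (0.34 log units; beyond the scatter) put the indole modestly ahead of plain 4-methoxyphenyl. For the measured compounds named here, the entering group here is 1-methyl-1H-indol-3-yl rather than 1H-indol-6-yl, with no hydrogen-bond donor left; no measured compound covers that exact group, so the indole precedent is only partly transferable. A small to modest rise is expected, a 1.9-fold higher number from compound 1 to compound 4 (0.28 log units; within the scatter), with compound 4 estimated at 260 nM in the range 100 nM to 700 nM.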

Compound 4, half-maximal inhibitory concentration: 1340 nM
Beside the measured number, compound 4's estimate is 5.2-fold (0.71 log units) below it; measured number outside the range, above it.
By their numbers in this assay, from the lowest: compounds 1 and 2 (each within the scatter of the next); then compound 3; then compound 4.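

In this assay, this place on the five-membered aromatic ring does not accept every indole equally: 1-methyl-1H-indol-3-yl trails 1H-indol-6-yl, with a 7.9-fold higher number from compound 2 to compound 4 (0.90 log units; beyond the scatter), so the match between compound 2 and compound 1 does not extend to indoles in general. The entering group also falls behind plain 4-methoxyphenyl, with a 3.6-fold higher number from compound 3 to compound 4 (0.55 log units; beyond the scatter), and replacing 3-amino-4-methoxyphenyl gives a 9.7-fold higher number from compound 1 to compound 4 (0.99 log units; beyond the scatter), the largest step among the compounds shown. No available evidence bears on the reason for this loss.

Between 1H-indol-6-yl and 1-methyl-1H-indol-3-yl, both the methyl and the point of attachment change, so the shown compounds cannot divide the step between them. Going by these compounds, how 1H-indol-3-yl or 1-methyl-1H-indol-6-yl would read out here remains open.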